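This account rests on a few compounds, and the source may have more. Where it says the series, first, only, none or still open, it means among the compounds named here.

Working notes on the series.

Compound 1 `C=C(Br)C(=O)Nc1ccc(/C=C/C(=O)c2ccc(OC)cc2)cc1` is the reference; in a functional assay on L1210 cells (Mus musculus) for antiproliferative activity, with a stated time of 48 h (a higher number here means a weaker inhibitor, a lower number a stronger inhibitor), compound 1 gives 980 nM. Compound 2 `C=C(Br)C(=O)Nc1ccc(/C=C/C(=O)c2ccc(OCC)cc2)cc1` differs from compound 1 by methyl in place of hydrogen on a saturated chain carbon bound to an oxygen on an aromatic ring; in this assay compound 2 gives 240 nM, a step of a 4.1-fold lower number from compound 1 to compound 2 (0.61 log units; beyond the scatter). Compound 3 `COc1ccc(C(=O)/C=C/c2ccc(N)cc2)cc1` has a different core; the two cores differ by hydrogen in place of (1-bromoethenyl)carbonyl on a nitrogen on an aromatic ring. In this assay compound 3 gives 160000 nM, which is the highest number of the three, with a step of a 160-fold higher number from compound 1 to compound 3 (2.21 log units; beyond the scatter).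

Compound 4 `CCOc1ccc(C(=O)/C=C/c2ccc(N)cc2)cc1` has not yet been measured. It differs from compound 3 by methyl in place of hydrogen on a saturated chain carbon bound to an oxygen on an aromatic ring, and the place of this change is worded identically for the pair compound 1 to compound 2, so it is the same change on the other core.

For compound 4 in this assay a step in the same direction is expected, but with no assurance that its size carries over, since the core of compound 3 lacks the amide; the expected step is a 2.9-fold lower number from compound 3 to compound 4 (0.46 log units; beyond the scatter), resting on the earlier step of a 4.1-fold lower number from compound 1 to compound 2 (0.61 log units; beyond the scatter). The estimate for compound 4 in this assay is 55000 nM, with a range from 18000 nM to 170000 nM.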

Compound 4, half-maximal inhibitory concentration: 21000 nM
Compound 4: middle estimate off by 2.6-fold (0.42 log units), on the high side; the measured number falls inside the stated range.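

In this assay, methyl in place of hydrogen on the saturated chain carbon bound to the oxygen gives a 7.6-fold lower number from compound 3 to compound 4 (0.88 log units; beyond the scatter), and this step agrees in direction with the earlier one and, within the scatter, in size: the same change on two cores in this assay, a 4.1-fold lower number (0.61 log units; beyond the scatter) from compound 1 to compound 2 and a 7.6-fold lower number (0.88 log units; beyond the scatter) from compound 3 to compound 4, 1.9-fold (0.27 log units) apart, within the scatter of two such steps. Hydrogen in place of (1-bromoethenyl)carbonyl on the nitrogen gives an 88-fold higher number from compound 2 to compound 4 (1.94 log units; beyond the scatter), which likewise agrees with the same change on the methoxy compounds: the same change on two cores in this assay, a 160-fold higher number (2.21 log units; beyond the scatter) from compound 1 to compound 3 and an 88-fold higher number (1.94 log units; beyond the scatter) from compound 2 to compound 4, 1.9-fold (0.27 log units) apart, within the scatter of two such steps. The two changes therefore behave as independent of each other across these four compounds, but this rests on a single pair per core and shows neither that the step would carry over to a third core nor why either change has its effect.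

Going by these compounds, it remains open whether a longer chain on the oxygen, such as propyl or butyl, would continue the step from methoxy to ethoxy. Also open, on these data alone, is how other groups on the nitrogen, such as acetyl or acryloyl, would compare with (1-bromoethenyl)carbonyl.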